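A Fourth Aryl Variant on a Shared Core

The source may hold more compounds than are shown below. What is called first, only, known or untested is meant among the compounds shown, and "the series" means these compounds.

Compound 1, `N#CC1=C(N)Oc2c(c3nc4ccccc4nc3c3ccccc23)C12C(=O)N(Cc1cnnn1-c1ccc(F)cc1)c1ccccc12`, gives in a functional assay on A549 cells (Homo sapiens) for antiproliferative activity, read by MTT assay, with a stated time of 48 h (a higher number here means a weaker inhibitor, a lower number a stronger inhibitor), only the assay's limit of > 50000 nM.
Compound 2, `N#CC1=C(N)Oc2c(c3nc4ccccc4nc3c3ccccc23)C12C(=O)N(Cc1cnnn1-c1ccc(Cl)cc1)c1ccccc12`, likewise gives only the limit of > 50000 nM.
Compound 3, `CC(=O)Nc1ccc(-n2nncc2CN2C(=O)C3(C(C#N)=C(N)Oc4c3c3nc5ccccc5nc3c3ccccc43)c3ccccc32)cc1`, gives only the limit of > 50000 nM.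

Compound 3 therefore stands at a limit rather than at a number, and the two other values shown share that position, since (the limit of > 50000 nM in this assay, at which 3 of the 3 values shown sit). The steps among the three measured compounds, a step that the two limits leave unreadable from compound 1 to compound 2, a step that the two limits leave unreadable from compound 1 to compound 3 and a step that the two limits leave unreadable from compound 2 to compound 3, are all unreadable for the same reason, so none of them gives a size to carry forward.

The unmeasured compound 4, `N#CC1=C(N)Oc2c(c3nc4ccccc4nc3c3ccccc23)C12C(=O)N(Cc1cnnn1-c1cc(Cl)ccc1Cl)c1ccccc12`, differs from compound 3 by 2,5-dichlorophenyl in place of 4-acetamidophenyl on an aromatic nitrogen. Within the data shown here, no measured step bears readably on this change, and the whole series so far sits at the limit. Compound 4 is therefore expected to be reported at that same limit, with an expected step of a number no higher from compound 3 to compound 4 (the limit leaves the size open), that is, none beyond the scatter. The estimate for compound 4 is 50000 nM, ranging from 20000 nM to 120000 nM.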

Compound 4, half-maximal inhibitory concentration: > 50000 nM
Compound 4: a limit, no number; the forecaster's own chance of this, stated with the estimate: 75%; the middle value sits exactly at the limit.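

No step from compound 1, compound 2 or compound 3 to compound 4 can be read in this assay, since all four compounds stand at one limit: the limit of > 50000 nM in this assay, at which 4 of the 4 values shown sit.

The compounds shown leave open whether changing the aryl group on the shared core alters antiproliferative activity at all.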